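A few compounds are considered here, and "the series" means these few. Any claim that something is new, unique, unknown or untested is made for them only; others in the source may bear on it.

Compound 1 `O=C(NO)c1ccc(NCc2nc(-c3ccccc3)nn2-c2ccc(Br)cc2)cc1`: 65.9%
Compound 2 `O=C(NO)c1ccc(NCc2nc(-c3cc4ccccc4s3)nn2-c2ccccc2)cc1`: 65.5%
Compound 3 `Cc1ccsc1-c1nc(CNc2ccc(C(=O)NO)cc2)n(-c2ccccc2)n1`: 72.1%

All three were tested in an assay on Sf9 cells for inhibition of protein deacetylase HDAC6 (Homo sapiens), read by fluorescence, with a stated time of 40 min, tested at 100 nM; on this read-out lower numbers stand for less inhibition and higher numbers for more inhibition at the one concentration tested (going by the name of the read-out). Compound 1 gives the second-highest of the three numbers, yet compound 2 and compound 3 both lie within the usual scatter of it. Going by the values given here, the only measured step, a number 6.6 percentage points higher from compound 2 to compound 3 (within the scatter), swaps a group on an aromatic carbon and stays within the scatter.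

Compound 4 `O=C(NO)c1ccc(NCc2nc(-c3ccccc3)nn2-c2ccccc2Cl)cc1` differs from compound 1 at a different place: 2-chlorophenyl in place of 4-bromophenyl on an aromatic nitrogen. Among the compounds with values here, no measured step changes the group on that aromatic nitrogen, so nothing here speaks directly to it. With every measured number close together, the expected step of a number 2.9 percentage points lower from compound 1 to compound 4 (within the scatter) is none beyond the scatter. Compound 4 is therefore estimated at 63%, with a range from 45% to 80%.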

Compound 4, a percentage reported as inhibition, at one concentration (the size of the read-out at that concentration, not a potency): 64.6%
Compound 4: middle estimate off by 1.6 percentage points, on the low side; the measured number falls inside the stated range.
By their numbers in this assay, from the lowest: compounds 4, 2, 1 and 3 (each within the scatter of the next).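

Going by these compounds alone, this is the first measured change to the group on the aromatic nitrogen: in this assay, 2-chlorophenyl in place of 4-bromophenyl gives a number 1.3 percentage points lower from compound 1 to compound 4 (within the scatter). The halogen and its place on the phenyl ring change together here, yet at the one concentration tested the two groups cannot be told apart. No evidence on hand bears on this result.

A 4-chlorophenyl group would separate the halogen from its place on the ring. On these data alone, it also remains open whether a phenyl ring carrying an amine or a carboxylic acid would read differently.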